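The source may report more compounds than this note shows. Statements on the series, on what has been measured and on what is new or still open speak of the compounds shown alone.

Measured compounds:
compound 1 `CC(C)(C)N(NC(=O)c1cccc(F)c1)C(=O)c1ccccc1Cl` – 69.2 nM
compound 2 `COc1cccc(C(=O)NN(C(=O)c2ccccc2Cl)C(C)(C)C)c1` – 52.5 nM

In an assay on cells for agonist activity at ecdysone receptor (Bombyx mori), read by a luciferase reporter, with a stated time of 24 h (a higher number here means that more compound is needed for the effect, a lower number that less compound is needed), compound 1 gives 69.2 nM and compound 2 gives 52.5 nM. Going by the values given here, the one step available, a 1.3-fold lower number from compound 1 to compound 2 (0.12 log units; within the scatter), does not separate the two compounds; compound 2 therefore stands level with compound 1 on this assay.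

Compound 3 `CC(C)(C)N(NC(=O)c1ccc(I)cc1)C(=O)c1ccccc1Cl` differs from compound 2 by 4-iodophenyl in place of 3-methoxyphenyl on a carbonyl carbon. Among the compounds with values here, no measured step covers this exchange: the step from compound 1 to compound 2 concerns a different group on the same aryl amide and was within the scatter, so it gives no direction for the change to compound 3. With both measured compounds close together, the expected outcome for compound 3 is a number near that of compound 2, with a step of a 1.1-fold higher number from compound 2 to compound 3 (0.06 log units; within the scatter) and no change beyond the scatter assumed. Compound 3 is estimated at 60 nM, with a range from 20 nM to 180 nM in this assay.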

Compound 3, half-maximal effective concentration: 7.59 nM
The estimate for compound 3 lay 7.9-fold (0.90 log units) above the measured number; the whole stated range lies above it.
By their numbers in this assay, from the lowest: compound 3; then compounds 2 and 1 (each within the scatter of the next).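

Unlike the exchange of fluoro for methoxy, replacing the aryl group on the carbonyl carbon whose other neighbour is the amide-type nitrogen moves the number beyond the scatter in this assay: 4-iodophenyl in place of 3-methoxyphenyl gives (a 6.9-fold lower number from compound 2 to compound 3 (0.84 log units; beyond the scatter)), and 4-iodophenyl in place of 3-fluorophenyl gives (a 9.1-fold lower number from compound 1 to compound 3 (0.96 log units; beyond the scatter)). The two steps agree in direction and show that this position tolerates a large change in the aryl group without loss in this assay. Nothing available explains the lower number for 4-iodophenyl.

Each step changes both the substituent and its place on the ring, so the contribution of iodine cannot be separated from that of its place. From the compounds shown here alone, how 4-fluorophenyl, 4-methoxyphenyl, or a phenyl ring carrying an amine or a carboxylic acid would compare with 4-iodophenyl remains open.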